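Swapping 4-chlorophenyl for 3-fluoropyridin-2-yl on the shared core

The compounds below may be only part of what the source reports. "The series", "measured", "known", "first", "only" and "open" are said of these compounds alone.

In a toxicity assay on J774.A1 cells (Mus musculus) for cytotoxicity, read by SYBR Green assay, with a stated time of 1 h (a lower number here means that less compound is needed, a higher number that more compound is needed for the effect), compound 3 (`CN(C)c1ccc2cc(-c3ccc(Cl)cc3)c(N)nc2c1`) gives 2900 nM. Compound 1 (`CN(C)c1ccc2cc(-c3ccccc3F)c(N)nc2c1`) gives 1600 nM, within the scatter of compound 3, with a 1.8-fold higher number from compound 1 to compound 3 (0.26 log units; within the scatter). Compound 2 (`CN(C)c1ccc2cc(-c3cccc(Cl)c3)c(N)nc2c1`) stands apart at 13000 nM, with an 8.1-fold higher number from compound 1 to compound 2 (0.91 log units; beyond the scatter) and a 4.5-fold lower number from compound 2 to compound 3 (0.65 log units; beyond the scatter). Compound 4 (`CN(C)c1ccc2cc(-c3ncccc3F)c(N)nc2c1`) differs from compound 3 in one place: 3-fluoropyridin-2-yl in place of 4-chlorophenyl on an aromatic carbon. Going by the values given here, no measured compound carries a ring with a hetero atom at this place, so the evidence is indirect. The 2-fluorophenyl of compound 1 and the 4-chlorophenyl of compound 3 show only a 1.8-fold higher number from compound 1 to compound 3 (0.26 log units; within the scatter), which points to a small change. The expected step, a 1.2-fold higher number from compound 3 to compound 4 (0.08 log units; within the scatter), lies within the scatter, with no firm direction. Compound 4 is estimated at 3500 nM, with an expected range of 1200 nM to 10000 nM.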

Compound 4, half-maximal effective concentration: 16000 nM
Beside the measured number, compound 4's estimate is 4.6-fold (0.66 log units) below it; measured number outside the range, above it.
By their numbers in this assay, from the lowest: compounds 1 and 3 (each within the scatter of the next); then compounds 2 and 4 (each within the scatter of the next).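

In this assay the first ring with a hetero atom at this place gives a 5.5-fold higher number from compound 3 to compound 4 (0.74 log units; beyond the scatter) and a 10-fold higher number from compound 1 to compound 4 (1.00 log units; beyond the scatter) while a 1.2-fold higher number from compound 2 to compound 4 (0.09 log units; within the scatter) shows no separable gap. The 3-fluoropyridin-2-yl group is therefore no small swap for 4-chlorophenyl or 2-fluorophenyl on this aromatic carbon. Nothing measured here offers a reason for the shift. Open, on these data alone, is whether the ring nitrogen or the fluorine carries the step, which an unsubstituted pyridin-2-yl group would test. A saturated ring such as morpholine at this place also remains unexplored in the compounds shown.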